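The compounds below may be only part of what the source reports. "The series", "measured", "known", "first", "only" and "open" are said of these compounds alone.

Compound 1 `COc1cc(-c2cc(/C=C/C(=O)c3ccc(N)cc3)[nH]n2)cc(OC)c1OC`: 102%
Compound 2 `COc1ccc(-c2cc(/C=C/C(=O)c3ccc(N)cc3)[nH]n2)cc1OC`: 101%

Compound 1 has the higher of the two numbers in a functional assay on NCI-H460 cells (Homo sapiens) for cytotoxicity, read by sulforhodamine B assay, with a stated time of 48 h, tested at 0.01 uM (a lower number here means a stronger effect, a higher number a weaker effect of the compound at the concentration tested), with compound 2 a single step away, a number 1 percentage points lower from compound 1 to compound 2 (within the scatter). Compound 3 `COc1ccc(C(=O)/C=C/c2cc(-c3cc(OC)c(OC)c(OC)c3)n[nH]2)cc1` has not yet been tested there. It differs from compound 1 by one change, (methoxy in place of amino on an aromatic carbon). Among the measured compounds shown here, no measured step involves this change; the only step known, from compound 1 to compound 2, concerns hydrogen in place of methoxy on an aromatic carbon and lies within the scatter. Both measured compounds show essentially no effect at this concentration, so compound 3 is expected to show a step of a number 2 percentage points lower from compound 1 to compound 3 (within the scatter), and its estimated value is 100%, ranging from 88% to 110%.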

Compound 3, a percentage reported as activity, at one concentration (the size of the read-out at that concentration, not a potency): 103%
The estimate for compound 3 lay 3 percentage points below the measured number; low and high end bracket the measured number.
By their numbers in this assay, from the lowest: compounds 2, 1 and 3 (each within the scatter of the next).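

In this assay, replacing 4-aminophenyl with 4-methoxyphenyl gives a number 1 percentage points higher from compound 1 to compound 3 (within the scatter). This is the first change shown at this position, and at this single low concentration it leaves no readable difference, so the free amino group is not required for the read-out seen here. No available measurement offers an explanation for this result. From the compounds shown here alone, whether the change would matter at concentrations where these compounds show a clear effect stays open. So does whether a carboxylic acid at this position would read differently.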